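The source may report more compounds than this note shows. Statements on the series, on what has been measured and on what is new or still open speak of the compounds shown alone.

Of the compounds shown here, three that share one core have been tested in a functional assay on SK-BR-3 cells (Homo sapiens) for cytotoxicity, read by MTT assay, with a stated time of 72 h; on this read-out higher numbers stand for an effect only at larger amounts of compound and lower numbers for an effect already at smaller amounts. Compound 1 `CCc1cccc2c(OC)c(-c3occ(C)c3C(=O)NC)ccc12` reaches only the limit of > 10 ug/mL. Compound 2 `CCOc1c(-c2occ(C)c2CO)ccc2c(CC)cccc12` gives 8.8 ug/mL. Compound 3 `CCc1cccc2c(OC(C)=O)c(-c3occ(C)c3COC(C)=O)ccc12` likewise reaches only the limit of > 10 ug/mL. So compound 3 stands at the limit of > 10 ug/mL in this assay, at which 2 of the 3 values shown sit, a limit rather than a number, and no step between two measured compounds that differ in one place can be drawn from these values.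

Compound 4 `CCOc1c(-c2occ(C)c2COC(C)=O)ccc2c(CC)cccc12` has not yet been measured. It differs from compound 3 by ethyl in place of acetyl on an oxygen on an aromatic ring; cut one bond further out, the change reads acetoxy to ethoxy. Like compound 4, compound 2 carries the ethoxy group, with hydroxymethyl rather than acetoxymethyl, and compound 2 gives 8.8 ug/mL. Because compound 3 sits at the limit of > 10 ug/mL in this assay, at which 2 of the 3 values shown sit, the size of the step cannot be read from the data. The expected step in this assay is none beyond the scatter, a number no higher from compound 3 to compound 4 (the limit leaves the size open), as an estimate only. Compound 4 is therefore expected to give about 10 ug/mL in this assay, with a range from 5 ug/mL to 20 ug/mL, and a fair chance that only a limit is reported again.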

Compound 4, concentration for half-maximal effect: > 10 ug/mL
Compound 4: a limit, no number; the forecaster's own chance of this, stated with the estimate: 50%; the middle value sits exactly at the limit.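

In this assay, compound 4 gives > 10 ug/mL, which is a limit and not a number, so acetoxy and ethoxy on an oxygen on an aromatic ring both leave the compound at a limit, and the step between compound 3 and compound 4 cannot be read. The new comparison that can be read keeps the ethoxy group and places acetyl in place of hydrogen on an oxygen on a saturated carbon, giving an at least 1.1-fold higher number from compound 2 to compound 4 (0.05 log units; that floor lies within the scatter); this is only a floor, so the data show no clear loss of effect, although the true step could be larger. With this result, the values gather at one edge of what the assay can report: the limit of > 10 ug/mL in this assay, at which 3 of the 4 values shown sit.

As far as these compounds go, how far compound 1, compound 3 and compound 4 lie beyond that limit remains open, so their order among themselves cannot be told. Also open, from the compounds shown here alone, is whether a longer chain such as butoxy or an amine-bearing chain on the aromatic oxygen, or a carboxylic acid in place of the acetoxymethyl group, would give a value clearly lower than that of compound 2.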